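Swapping the side chain: from compound 3 to compound 4

The source may hold more compounds than are shown below. What is called first, only, known or untested is meant among the compounds shown, and "the series" means these compounds.

Of the compounds shown here, three of one series have been tested in a functional assay on A-375 cells (Homo sapiens) for cytotoxicity, read by MTT assay; a higher number here means a weaker inhibitor, a lower number a stronger inhibitor. Compound 1, `O=S(=O)(NCCCNc1nccc(-c2c(-c3cccc(F)c3)nc3sccn23)n1)c1cccc(F)c1`, gives 13700 nM. Compound 2, `O=C(NCCNc1nccc(-c2c(-c3cccc(F)c3)nc3sccn23)n1)c1c(F)cccc1F`, gives 2700 nM. Compound 3, `O=S(=O)(NCCCNc1nccc(-c2c(-c3cccc(F)c3)nc3sccn23)n1)c1ccc(Cl)cc1`, gives 5900 nM, the second highest of the three numbers. The next compound is compound 4, `Cc1ccc(C(=O)NCCNc2nccc(-c3c(-c4cccc(F)c4)nc4sccn34)n2)cc1`. It differs from compound 3 in one place: ((4-methylphenyl)carbonyl)amino in place of (((4-chlorophenyl)sulfonyl)amino)methyl on a saturated chain carbon, two bonds along the chain from a nitrogen on an aromatic ring. The closest measured step is a 5.1-fold lower number from compound 1 to compound 2 (0.71 log units; beyond the scatter), which trades the same kind of group in the same place, and its counterpart is a 2.2-fold higher number from compound 2 to compound 3 (0.34 log units; beyond the scatter). Compound 4 also shares its whole side chain type with compound 2. A modest downward step is therefore expected, a 2.4-fold lower number from compound 3 to compound 4 (0.37 log units; beyond the scatter). For compound 4 the estimate in this assay is 2500 nM, with a range from 1000 nM to 7000 nM.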

Compound 4, half-maximal inhibitory concentration: 5880 nM
For compound 4 the middle estimate is 2.4-fold (0.37 log units) below the measured one; the measured number falls inside the stated range.
By their numbers in this assay, from the lowest: compound 2; then compounds 4 and 3 (each within the scatter of the next); then compound 1.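

The side-chain swap gives a 1.0-fold lower number from compound 3 to compound 4 (0.00 log units; within the scatter) in this assay, so a carbonyl side chain does not by itself bring the low number of compound 2. The aromatic group on the carbonyl carbon counts as well: 4-methylphenyl in place of 2,6-difluorophenyl gives a 2.2-fold higher number from compound 2 to compound 4 (0.34 log units; beyond the scatter), while the swap from the other sulfonyl side chain gives a 2.3-fold lower number from compound 1 to compound 4 (0.37 log units; beyond the scatter). Nothing shown explains these steps.

The swap changes the linking group and the chain together, so their shares stay unresolved. A longer chain carrying the 2,6-difluorophenyl carbonyl group could begin to separate them.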